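This account rests on a few compounds, and the source may have more. Where it says the series, first, only, none or still open, it means among the compounds named here.

Measured so far in a functional assay on VSMC cells (Rattus norvegicus); on this read-out higher numbers stand for weaker inhibition and lower numbers for stronger inhibition:
- compound 1 `Cc1c(O)c(C)c2c(c1O)C(=O)CC(c1ccc(Cl)cc1)O2`: "not active" (no number reported)
- compound 2 `COc1ccc(C2CC(=O)c3c(O)c(C)c(O)c(C)c3O2)cc1`: > 100000 nM

Compound 1 gave no number in this assay and is recorded as not active. Among the compounds with values here, compound 2 sits at a limit of this assay, not at a measured number, as the only value of its kind here (the limit of > 100000 nM in this assay, at which 1 of the 2 values shown sits). Neither entry gives a point from which a step could be sized, so the series as measured carries no information on which change moves the read-out.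

The next compound, compound 3 `COc1ccc(C2CC(=O)c3c(O)c(C)c(O)c(C)c3O2)c(OC)c1`, differs from compound 2 by methoxy in place of hydrogen on an aromatic carbon.

With both measured compounds outside the range of the assay, no step beyond the scatter is expected in this assay; the methoxy added is expected to leave compound 3 where compound 2 stands. The step from compound 2 to compound 3, a step that the limit leaves unreadable from compound 2 to compound 3, is estimated as none beyond the scatter. Compound 3 is expected at about 150000 nM, with a range of 50000 nM to 500000 nM, and most likely again reported only as a limit.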

Compound 3, half-maximal inhibitory concentration: "not active" (no number reported)
The entry for compound 3 holds no number; there is nothing to compare the estimate with.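

No step can be read between compound 2 and compound 3 in this assay, since compound 3 carries no number and compound 2 stands at a limit: the limit of > 100000 nM in this assay, at which 1 of the 3 values shown sits. The compounds shown leave open whether any single change on the shared core moves the read-out.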